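A few compounds are considered here, and "the series" means these few. Any claim that something is new, unique, unknown or untested is made for them only; others in the source may bear on it.

Measured in a functional assay on G-361 cells (Homo sapiens) for antiproliferative activity, with a stated time of 72 h; a lower number here means a stronger inhibitor, a higher number a weaker inhibitor:
- compound 1 `COc1ccc(CNc2ncnc3c2ncn3[C@@H]2O[C@H](CO)[C@@H](O)[C@H]2O)c(OC)c1`: "not determined" (no result reported)
- compound 2 `OC[C@H]1O[C@@H](n2cnc3c(NCc4ccc(F)cc4F)ncnc32)[C@H](O)[C@@H]1O`: > 166000 nM (a limit)

Compound 2 stands in this assay only as a limit, > 166000 nM, and not as a number. For the measured compounds named here, compound 1 offers no result for comparison, so the series has no measured step to scale from.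

Compound 3 `OC[C@H]1O[C@@H](n2cnc3c(NCc4ccc(F)c(Cl)c4)ncnc32)[C@H](O)[C@@H]1O` is the next to be read. It has 3-chloro-4-fluorophenyl in place of 2,4-difluorophenyl on a saturated chain carbon bound to a nitrogen on an aromatic ring. The same difference reads as 2,4-difluorobenzyl to 3-chloro-4-fluorobenzyl.

The expectation rests on compound 2 alone, with its limit of > 166000 nM. The expected change is an at least 2.7-fold lower number from compound 2 to compound 3 (0.44 log units; beyond the scatter), in the direction of stronger inhibition, although another limit is quite possible. For compound 3 the estimate is 60000 nM, with an expected range of 5000 nM to 166000 nM.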

Compound 3, half-maximal inhibitory concentration: > 166000 nM
Compound 3 was reported as a limit (the forecaster's own chance of this, stated with the estimate: 55%); at least 2.7-fold (0.44 log units) between middle value and limit.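

Compound 2 and compound 3 both stand only as limits in this assay, so no step can be read between them. The compounds shown leave open whether any benzyl group on the shared core gives a measurable value in this assay: the limit of > 166000 nM in this assay, at which 2 of the 3 values shown sit.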